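Triazole-Linked Oxime Ethers: Phenyl Substitution and Cytotoxicity

A few compounds are considered here, and "the series" means these few. Any claim that something is new, unique, unknown or untested is made for them only; others in the source may bear on it.

Measured compounds:
compound 1 `CC(C)=CCC/C(C)=C/CC/C(C)=C/CC[C@@H]1[C@@]2(C)CC/C(=N\OCc3cn(-c4ccccc4)nn3)C(C)(C)[C@@H]2CC[C@@]1(C)O` — 9590 nM
compound 2 `CC(C)=CCC/C(C)=C/CC/C(C)=C/CC[C@@H]1[C@@]2(C)CC/C(=N\OCc3cn(-c4cccc([N+](=O)[O-])c4)nn3)C(C)(C)[C@@H]2CC[C@@]1(C)O` — 20700 nM

In a functional assay on MCF7 cells (Homo sapiens) for cytotoxicity, read by MTT assay, with a stated time of 48 h (on this read-out lower numbers stand for stronger inhibition and higher numbers for weaker inhibition), compound 1 gives 9590 nM, the lowest of the two numbers recorded; its nearest neighbour is compound 2, and the step of a 2.2-fold higher number from compound 1 to compound 2 (0.33 log units; beyond the scatter) separates them. Compound 3 `COc1cc(OC)c(-n2cc(CO/N=C3\CC[C@]4(C)[C@@H](CC/C=C(\C)CC/C=C(\C)CCC=C(C)C)[C@](C)(O)CC[C@H]4C3(C)C)nn2)c(OC)c1` is not yet measured. It differs from compound 1 as follows: 2,4,6-trimethoxyphenyl in place of phenyl on an aromatic nitrogen. For the measured compounds named here, the only measured step that bears on this change is the one from compound 1 to compound 2, which also alters the phenyl on the aromatic nitrogen; that step, a 2.2-fold higher number from compound 1 to compound 2 (0.33 log units; beyond the scatter), was modest and ran toward a higher number. Going by the values given here, compound 3 is therefore expected to move in the same direction by a similar, modest amount, a 1.5-fold higher number from compound 1 to compound 3 (0.16 log units; within the scatter), though the change is larger and the single precedent gives little certainty. Compound 3 is estimated at 14000 nM, within a range of 5000 nM to 35000 nM.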

Compound 3, half-maximal inhibitory concentration: 14700 nM
Beside the measured number, compound 3's estimate is 1.1-fold (0.02 log units) below it; measured number inside the range.
By their numbers in this assay, from the lowest: compounds 1, 3 and 2 (each within the scatter of the next, the first and the last beyond it).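

In this assay the 2,4,6-trimethoxyphenyl group on the aromatic nitrogen, with 12 heavy atoms where phenyl has 6, gives a 1.5-fold higher number from compound 1 to compound 3 (0.19 log units; within the scatter) and also a 1.4-fold lower number from compound 2 to compound 3 (0.15 log units; within the scatter) and so cannot be told apart from either compound. The position thus takes this much larger aryl group without a step beyond the scatter, whereas the smaller nitro change in a 2.2-fold higher number from compound 1 to compound 2 (0.33 log units; beyond the scatter) did go beyond it, so among these compounds the number of added atoms does not track the size of the step. Nothing available explains these numbers.

The compounds shown leave open how an amine or a carboxylic acid on the phenyl would read, and whether a single methoxy group would behave as the three together do. They also leave open whether a benzyl group or a longer chain on the aromatic nitrogen would give a number clearly lower than that of compound 1.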